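A few compounds are considered here, and "the series" means these few. Any claim that something is new, unique, unknown or untested is made for them only; others in the source may bear on it.

Compounds measured so far:
compound 1, `CCOc1cccc(-c2ccc(CN(C(=O)C3CCCCC3)c3cccc(/C=C/C(=O)OC)c3)cc2)c1`, 147 nM
compound 2, `COC(=O)/C=C/c1cccc(N(Cc2ccc(-c3ccc(OC)cc3)cc2)C(=O)C2CCCCC2)c1`, 89 nM
compound 3, `COC(=O)/C=C/c1cccc(N(Cc2ccc(-c3ccc(OC)cc3)cc2)C(=O)C(C)C)c1`, 97 nM

The three compounds were tested in an assay on isolated protein with Bile acid receptor (Homo sapiens) as the target; on this read-out higher numbers stand for an effect only at larger amounts of compound and lower numbers for an effect already at smaller amounts. Compound 3 gives 97 nM, the second highest of the three numbers; it sits nearest to compound 2, at 89 nM, and furthest from compound 1, at 147 nM, though all three lie within the scatter of one another, so no order among them can be claimed.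

Compound 4, `COC(=O)/C=C/c1cccc(N(Cc2ccc(-c3ccc(F)c(Cl)c3)cc2)C(=O)C(C)C)c1`, differs from compound 3 in one place: 3-chloro-4-fluorophenyl in place of 4-methoxyphenyl on an aromatic carbon. Of the measured steps, only a 1.7-fold lower number from compound 1 to compound 2 (0.22 log units; within the scatter) touches the same aromatic carbon, and it exchanged one alkoxy-bearing ring for another; the step of a 1.1-fold higher number from compound 2 to compound 3 (0.04 log units; within the scatter) concerns the carbonyl carbon and does not bear on this change. For the measured compounds named here, no measured step replaces a methoxy group with halogens, so the data offer no direct guide, and the one relevant step was small.

On that basis compound 4 is expected to show little movement in this assay, an expected step of a 1.1-fold higher number from compound 3 to compound 4 (0.05 log units; within the scatter), in no particular direction beyond the scatter. The estimate for compound 4 is 110 nM, with a range from 45 nM to 270 nM.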

Compound 4, half-maximal effective concentration: 129 nM
Estimate against measurement, compound 4: 1.2-fold (0.07 log units) below, within the range that was stated.
By their numbers in this assay, from the lowest: compounds 2, 3, 4 and 1 (each within the scatter of the next).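

In this assay, for the compounds shown here, the exchange of 4-methoxyphenyl for 3-chloro-4-fluorophenyl gives a 1.3-fold higher number from compound 3 to compound 4 (0.12 log units; within the scatter), which is the first reading at this aromatic carbon, para to a large group, of a ring carrying halogens and no alkoxy group. The earlier step at this carbon, a 1.7-fold lower number from compound 1 to compound 2 (0.22 log units; within the scatter), only swapped one alkoxy-bearing ring for another, whereas this one shows that the number stays within the scatter even when the oxygen goes and the count of hydrogen-bond acceptors in the group falls from 1 to 0 while the heavy-atom count stays at 8. Nothing available here accounts for that outcome.

The chlorine and the fluorine entered together, so their separate contributions cannot be told apart, and the compounds shown leave open whether a 4-fluorophenyl or a 3-chlorophenyl alone would stay within the scatter of compound 4. They also leave open how the number would respond to an amine or a carboxylic acid on this ring, or to a carboxylic acid in place of the methyl ester that all four compounds share.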